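The compounds below may be only part of what the source reports. "The series", "measured", "known", "first", "only" and "open" are said of these compounds alone.

Compound 3 `CCCC(C(C)C)n1ccc2cc(/C(C)=C/C(=O)Nc3ccccc3OCCCC(=O)O)ccc21` gives the lowest number of the three measured in an assay on Prostate gland for inhibition of steroid 5-alpha-reductase (Rattus norvegicus) (on this read-out lower numbers stand for stronger inhibition and higher numbers for weaker inhibition), at 7.2 nM; compound 2 `CCCC(CC)n1ccc2cc(/C(C)=C/C(=O)Nc3ccccc3OCCCC(=O)O)ccc21` gives 9.3 nM and compound 1 `CCC(C)n1ccc2cc(/C(C)=C/C(=O)Nc3ccccc3OCCCC(=O)O)ccc21` gives 67 nM. Compound 4 `C/C(=C\C(=O)Nc1ccccc1OCCCC(=O)O)c1ccc2c(ccn2Cc2ccc(C)cc2)c1` differs from compound 3 by 4-methylbenzyl in place of 1-isopropylbutyl on an aromatic nitrogen. Within the data shown here, every measured step so far alters the substituent on that same aromatic nitrogen: a 7.2-fold lower number from compound 1 to compound 2 (0.86 log units; beyond the scatter), a 9.3-fold lower number from compound 1 to compound 3 (0.97 log units; beyond the scatter) and a 1.3-fold lower number from compound 2 to compound 3 (0.11 log units; within the scatter). Among the measured compounds shown here, the two steps away from compound 1 each lowered the number by a modest amount, but no measured compound carries an aromatic ring at this position, so the exchange of a branched alkyl for a benzyl group has no direct precedent here. The expected step from compound 3 to compound 4 is a 2.1-fold higher number from compound 3 to compound 4 (0.32 log units; beyond the scatter). Compound 4 is estimated at 15 nM, within a range of 4 nM to 60 nM.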

Compound 4, half-maximal inhibitory concentration: 88 nM
Estimate against measurement, compound 4: 5.9-fold (0.77 log units) below; measured number outside the range, above it.
By their numbers in this assay, from the lowest: compounds 3 and 2 (each within the scatter of the next); then compounds 1 and 4 (each within the scatter of the next).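

In this assay, among these compounds, 4-methylbenzyl is the first aromatic ring on this aromatic nitrogen, and it does not hold the level of the larger branched alkyl groups: a 12-fold higher number from compound 3 to compound 4 (1.09 log units; beyond the scatter) and a 9.5-fold higher number from compound 2 to compound 4 (0.98 log units; beyond the scatter). Against sec-butyl, the result is a 1.3-fold higher number from compound 1 to compound 4 (0.12 log units; within the scatter). Heavy-atom count alone therefore does not order this position, as 4-methylbenzyl has 8 and 1-isopropylbutyl has 7. Nothing available explains this result. Open, from the compounds shown here alone, is whether benzyl, 4-methoxybenzyl or cyclohexylmethyl on this nitrogen would track 4-methylbenzyl or the branched alkyl groups.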